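The source may hold more compounds than are shown below. What is called first, only, known or untested is meant among the compounds shown, and "the series" means these compounds.

Two compounds of the series carry a measured number in a functional assay on cells (Erythrocyte, Homo sapiens) for inhibition, read by spectrophotometry and hemolysis, with a stated time of 10 min; a higher number here means a weaker inhibitor, a lower number a stronger inhibitor. Compound 1 `Cc1cccc2nc(N/N=C\c3ccc(Br)cc3Br)sc12` gives 10.1 ug/mL in this assay. Compound 2 `Cc1cccc2nc(N/N=C/CC(C)C)sc12` gives 90.7 ug/mL. Going by the values given here, compound 2 stands at the highest of the two numbers; its only neighbour is compound 1, whose lower number lies beyond the scatter, so compound 2 is the weaker inhibitor of the pair. Compound 3 `CCCCCC/C=N/Nc1nc2cccc(C)c2s1` has not been measured in this assay. It differs from compound 2 in one place: pentyl in place of isopropyl on a saturated chain carbon bound to a carbon with a double bond to nitrogen. Among the compounds with values here, no step between measured compounds covers a change of this kind, and the two measured values say nothing about chain length on their own. The step from compound 2 to compound 3 is therefore expected to be small, a modest move toward a lower number at best and possibly none beyond the scatter, estimated as a 1.5-fold lower number from compound 2 to compound 3 (0.18 log units; within the scatter). For compound 3 the estimate is 60 ug/mL, with a range from 25 ug/mL to 150 ug/mL.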

Compound 3, half-maximal inhibitory concentration: 82.2 ug/mL
Beside the measured number, compound 3's estimate is 1.4-fold (0.14 log units) below it, and the stated range covers the measured number.
By their numbers in this assay, from the lowest: compound 1; then compounds 3 and 2 (each within the scatter of the next).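

Read as a single change at this place, pentyl in place of isopropyl gives a 1.1-fold lower number from compound 2 to compound 3 (0.04 log units; within the scatter) in this assay, the first step between measured compounds in the series. On a saturated chain carbon bound to a carbon with a double bond to nitrogen, these two chains therefore cannot be told apart in this assay, and the same holds when the difference is read as isobutyl to hexyl. Nothing measured bears on the reason for this result.

On these data alone, whether a longer chain such as decyl, or a chain ending in an amine or a carboxylic acid, would also stay within the scatter of compound 2 remains open. Also open, as far as these compounds go, is how a saturated ring such as cyclohexyl would read at this same place.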